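Cyclopropyl to cycloheptyl, repeated at a second ring nitrogen

The compounds below may be only part of what the source reports. "The series", "measured", "known", "first", "only" and "open" are said of these compounds alone.

In an ADME assay on HEK-293T cells (Homo sapiens) for cytotoxicity, read by resazurin assay, with a stated time of 16 h (a higher number here means a weaker inhibitor, a lower number a stronger inhibitor), the three measured compounds stand as follows:
compound 1 `OC[C@H]1O[C@@H](n2cnc3c(NC4CCCC4)nc(NC4CCCCCC4)nc32)[C@H](O)[C@@H]1O` gives 167000 nM;
compound 2 `OC[C@H]1O[C@@H](n2cnc3c(NC4CCCC4)nc(NC4CC4)nc32)[C@H](O)[C@@H]1O` gives only a limit of the assay, > 500000 nM;
compound 3 `OC[C@H]1O[C@@H](n2cnc3c(NC4CC4)nc(NC4CCCC4)nc32)[C@H](O)[C@@H]1O` likewise gives only a limit, > 500000 nM.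

Compound 2 differs from compound 1 by cycloheptyl in place of cyclopropyl on a nitrogen on an aromatic ring, and that change made an at least 2.9-fold lower number from compound 2 to compound 1 (0.47 log units; beyond the scatter), a step whose size is only known as a bound because of the limit of > 500000 nM in this assay, at which 2 of the 3 values shown sit. Compound 3 has the same atoms as compound 2 joined differently; the difference between the two cores is not broken down here. Compound 4 `OC[C@H]1O[C@@H](n2cnc3c(NC4CCCCCC4)nc(NC4CCCC4)nc32)[C@H](O)[C@@H]1O` differs from compound 3 by cycloheptyl in place of cyclopropyl on a nitrogen on an aromatic ring, the same change in the same kind of place. A step like the earlier one is expected, so the estimated change is an at least 2.5-fold lower number from compound 3 to compound 4 (0.39 log units; beyond the scatter), resting on compound 2 giving > 500000 nM and compound 1 giving 167000 nM. Compound 4 is expected to give about 200000 nM, plausibly between 70000 nM and 600000 nM.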

Compound 4, half-maximal inhibitory concentration: > 500000 nM
Compound 4 was reported as a limit; the forecaster's own chance of this, stated with the estimate: 30%; middle value at least 2.5-fold (0.39 log units) away from the limit.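

The step from compound 3 to compound 4 in this assay cannot be read, since both compounds give only a limit: the limit of > 500000 nM in this assay, at which 3 of the 4 values shown sit.

From the compounds shown here alone, whether cycloheptyl in place of cyclopropyl lowers the number at all in compound 4, as it does from compound 2 to compound 1, stays open.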